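A few compounds are considered here, and "the series" means these few. Any claim that something is new, unique, unknown or untested is made for them only; others in the source may bear on it.

In a functional assay on DU-145 cells (Homo sapiens) for inhibition, read by sulforhodamine B assay, with a stated time of 48 h (a higher number here means that more compound is tolerated, a lower number that less compound is tolerated), compound 1 `CCOC(=O)[C@H](CCC(=O)O)NC(=O)c1ccc(CNc2nc3cc(N)cc(N)c3nc2-c2ccccc2)cc1` gives only a limit of the assay, < 100000 nM. Compound 2 `Nc1cc(N)c2nc(-c3ccccc3)c(NCc3ccc(F)cc3)nc2c1` gives 9770 nM in this assay, and compound 3 `COc1ccc(Sc2nc3cc(N)cc(N)c3nc2-c2ccccc2)cc1` gives 69200 nM. Of the two numbers available, compound 3 therefore stands with the higher one, and the exchange that leads to it, (4-methoxyphenyl)sulfanyl in place of (4-fluorobenzyl)amino on an aromatic carbon, shows a 7.1-fold higher number from compound 2 to compound 3 (0.85 log units; beyond the scatter). Compound 4 `Nc1cc(N)c2nc(-c3ccccc3)c(Oc3ccc(F)cc3)nc2c1` differs from compound 3 by 4-fluorophenoxy in place of (4-methoxyphenyl)sulfanyl on an aromatic carbon. No measured step covers this exchange directly; the only step shown, a 7.1-fold higher number from compound 2 to compound 3 (0.85 log units; beyond the scatter), concerns the replacement that separates compound 2 from compound 3, and compound 4 carries a group resembling parts of both. He therefore expects compound 4 to sit between the two measured neighbours, probably closer to compound 3, so that a 1.7-fold lower number from compound 3 to compound 4 (0.24 log units; within the scatter) is estimated as a modest move toward lower numbers, possibly within the scatter. His estimate for compound 4 in this assay is 40000 nM, with a range from 10000 nM to 100000 nM.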

Compound 4, concentration lethal to 50% of the cells: < 100000 nM
Compound 4 gave a limit, no number; the forecaster's own chance of this, stated with the estimate: 25%; the middle value does not contradict the limit.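

In this assay compound 4 gives < 100000 nM, which is a limit of the assay, and the steps to it from compound 2 and compound 3 cannot be read. The compounds shown leave open where compound 4 stands relative to compound 2 and compound 3.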